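The source may hold more compounds than are shown below. What is called first, only, known or untested is meant among the compounds shown, and "the series" means these compounds.

The compounds measured in a functional assay on A549 cells (Homo sapiens) for cytotoxicity, read by MTT assay, with a stated time of 48 h (a higher number here means that more compound is needed for the effect, a lower number that less compound is needed), so far:

Compound 1 `CO[C@H]1O[C@H](COc2ccc(OC3CCCCC3)cc2)[C@@H](O)[C@H](O)[C@H]1Oc1ccc(C(C)C)cc1`: 27000 nM
Compound 2 `CO[C@H]1O[C@H](COc2ccc(OC3CCCCC3)cc2)[C@@H](O)[C@H](O)[C@H]1Oc1ccc(OC2CCCCC2)cc1`: 18000 nM
Compound 3 `CO[C@H]1O[C@H](COc2ccc(C3CCCCC3)cc2)[C@@H](O)[C@H](O)[C@H]1Oc1ccc(OC2CCCCC2)cc1`: 12000 nM

Compound 2 stands second highest of these three numbers in this assay, nearest to compound 1. The steps of a 1.5-fold lower number from compound 1 to compound 2 (0.18 log units; within the scatter) and a 1.5-fold lower number from compound 2 to compound 3 (0.18 log units; within the scatter) both lie within the scatter, so the three compounds are not separated by the data. Compound 4 `CO[C@@H]1O[C@H](COc2ccc(OC3CCCCC3)cc2)[C@@H](O)[C@H](O)[C@H]1Oc1ccc(OC2CCCCC2)cc1` has not been measured. Its difference from compound 2 is the two compounds have the same atoms and bonds and differ only in configuration as drawn: 1 of 5 stereo elements differ; a stereocentre at a saturated ring carbon is drawn S in compound 2 and R in compound 4. Neither measured step concerns a change of configuration, so none bears directly on this one, and the series as a whole has moved little. No step beyond the scatter is therefore expected in this assay. Compound 4 is estimated at 18000 nM, with a range from 7000 nM to 45000 nM. This amounts to an expected step of no change at the digits printed from compound 2 to compound 4 (within the scatter).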

Compound 4, half-maximal effective concentration: 25000 nM
The estimate for compound 4 lay 1.4-fold (0.14 log units) below the measured number; measured number inside the range.
By their numbers in this assay, from the lowest: compounds 3, 2, 4 and 1 (each within the scatter of the next, the first and the last beyond it).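

In this assay, within the data shown here, this is the first change of configuration, and inverting this stereocentre at a saturated ring carbon gives a 1.4-fold higher number from compound 2 to compound 4 (0.14 log units; within the scatter), so the inversion does not separate the pair. The comparison concerns configuration alone: the fact that compounds 2 and 4 differ only in the configuration as drawn

As far as these compounds go, whether the same inversion would also stay within the scatter alongside the isopropyl group of compound 1 or the cyclohexyl group of compound 3 remains open. From the compounds shown here alone, it is also open whether an amine or a carboxylic acid in place of cyclohexyloxy on an aromatic carbon would move the number beyond the scatter.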